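The compounds below may be only part of what the source reports. "The series", "measured", "known", "first", "only" and "open" are said of these compounds alone.

Measured so far in a functional assay (Homo sapiens) for inhibition of Nucleic Acid, tested at 100 uM; on this read-out higher numbers stand for more inhibition at the one concentration tested (going by the name of the read-out) and lower numbers for less inhibition:

- compound 1 `OC[C@H]1O[C@@H](n2cnc3c(NCc4ccccc4)nccc32)C[C@@H]1O`: 15%
- compound 2 `[O-][n+]1ccc2c(c1)ncn2[C@H]1C[C@H](O)[C@@H](CO)O1`: 0%
- compound 3 `OC[C@H]1OC(n2cnc3c(NCc4ccccc4)nccc32)[C@H](O)[C@@H]1O`: 32%

Compound 3 stands highest of the three numbers in this assay. The nearest is compound 1, whose number lies below it by a margin beyond the scatter; the furthest is compound 2, whose number lies below it by a wider margin, also beyond the scatter. Among the compounds with values here, no pair of measured compounds differs in only one place, so no single-step comparison is available within the measured set.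

Compound 4 `CN(C)c1nccc2c1ncn2C1O[C@H](CO)[C@@H](O)[C@H]1O` differs from compound 3 in one place: dimethylamino in place of benzylamino on an aromatic carbon. Within the data shown here, the measured set offers no direct precedent for this exchange. Among the measured compounds shown here, compound 2, the only measured compound carrying no amino substituent of this kind, gives 0%. On that basis, the step from compound 3 to compound 4 in this assay is expected to run downward and beyond the scatter, estimated as a number 22 percentage points lower from compound 3 to compound 4 (beyond the scatter). Compound 4 is accordingly expected to give 10% in this assay, within a range of 0% to 25%.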

Compound 4, a percentage reported as inhibition, at one concentration (the size of the read-out at that concentration, not a potency): 0%
Compound 4: middle estimate off by 10 percentage points, on the high side; the measured number falls inside the stated range.
By their numbers in this assay, from the lowest: compounds 2 and 4 (each within the scatter of the next); then compound 1; then compound 3.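

In this assay, within the data shown here, dimethylamino in place of benzylamino on the aromatic carbon next to the ring nitrogen gives the first one-place comparison, a large step: a number 32 percentage points lower from compound 3 to compound 4 (beyond the scatter). The read-out at this position therefore depends on the group it carries, though benzylamino takes its six-membered aromatic ring of carbon and its hydrogen-bond donor with it in the same exchange, so this single step cannot separate the two. Nothing measured independently accounts for the size of the step.

On these data alone, whether the aromatic ring or the amino hydrogen matters more remains open. Methylamino would keep the hydrogen-bond donor without the ring, while N-methylbenzylamino would keep the ring without the donor, and phenethylamino would test a longer chain to the ring.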